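Pyridine-linked hydroxyphenyl thiophenes: limits only so far

A few compounds are considered here, and "the series" means these few. Any claim that something is new, unique, unknown or untested is made for them only; others in the source may bear on it.

Measured compounds, each a limit rather than a number:
compound 1 `Oc1ccc(-c2cc(-c3cccs3)cc(-c3ccccc3O)n2)cc1` gives > 50000 nM in a functional assay on DU-145 cells (Homo sapiens) for cytotoxicity, read by CCK-8 assay; a lower number here means a stronger inhibitor, a higher number a weaker inhibitor
compound 2 `Oc1ccccc1-c1cc(-c2ccsc2)cc(-c2ccccc2O)n1` gives > 50000 nM in this assay
compound 3 `Oc1ccc(-c2cc(-c3ccsc3)cc(-c3ccccc3O)n2)cc1` gives > 50000 nM in this assay

Compound 3 stands at the limit, as do the other two values shown, in line with the limit of > 50000 nM in this assay, at which 3 of the 3 values shown sit. Going by the values given here, the steps that bear on it, a step that the two limits leave unreadable from compound 1 to compound 3 and a step that the two limits leave unreadable from compound 2 to compound 3, cannot be sized because both ends sit at the limit. Compound 4 `Oc1ccc(-c2cc(-c3ccsc3)cc(-c3ccc(O)cc3)n2)cc1` differs from compound 3 by 4-hydroxyphenyl in place of 2-hydroxyphenyl on an aromatic carbon. The related step that the two limits leave unreadable from compound 2 to compound 3 gives no readable size, so no shift beyond the scatter is expected. Compound 4 is expected at 60000 nM (range 20000 nM to 200000 nM), a step that the limit leaves unreadable from compound 3 to compound 4, most likely again a limit.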

Compound 4, half-maximal inhibitory concentration: 2060 nM
Beside the measured number, compound 4's estimate is 29-fold (1.46 log units) above it, outside the stated range (below it).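

In this assay, going by these compounds alone, the change at the position next to the ring nitrogen, 4-hydroxyphenyl in place of 2-hydroxyphenyl, gives an at least 24-fold lower number from compound 3 to compound 4 (1.38 log units; beyond the scatter) and is the first step that can be sized. The same exchange from compound 2 to compound 3 could not be read, so the effect appears only once no 2-hydroxyphenyl group remains. Within the data shown here, compound 4 is the only compound off the limit: the limit of > 50000 nM in this assay, at which 3 of the 4 values shown sit.

Still open, going by these compounds, is whether thiophen-2-yl in place of thiophen-3-yl keeps this value with both 4-hydroxyphenyl groups present. Also open, on these data alone, is whether an amine or a carboxylic acid can stand in for the hydroxyl groups.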